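This account rests on a few compounds, and the source may have more. Where it says the series, first, only, none or still open, it means among the compounds named here.

Compound 1 `c1cc(CNC2CCN(CCCc3c[nH]c4ccc(-n5cnnc5)cc34)CC2)co1` gives 7.1 nM in an assay on CHO cells for agonist activity at 5-hydroxytryptamine receptor 1D (Homo sapiens), read by GTPgammaS binding; on this read-out lower numbers stand for an effect already at smaller amounts and higher numbers for an effect only at larger amounts of compound.
Compound 2 `OCCC(NC1CCN(CCCc2c[nH]c3ccc(-n4cnnc4)cc23)CC1)c1ccccc1` gives 5.1 nM in this assay.

Within the data shown here, of the two numbers measured so far, compound 2 holds the lower one, but the step of a 1.4-fold lower number from compound 1 to compound 2 (0.14 log units; within the scatter) is within the scatter, so the two compounds cannot be told apart on this read-out. Among the measured compounds shown here, that single step is the only measured comparison available, and it exchanged the whole group on the amine nitrogen, 3-hydroxy-1-phenylpropyl in place of (furan-3-yl)methyl, without any change beyond the scatter.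

Compound 3 `c1ccc(CNC2CCN(CCCc3c[nH]c4ccc(-n5cnnc5)cc34)CC2)cc1` is not yet measured. It differs from compound 2 in one place: hydrogen in place of 2-hydroxyethyl on a saturated chain carbon bound to an amine nitrogen and an aromatic carbon. Cut one bond further out, this reads as benzyl in place of 3-hydroxy-1-phenylpropyl on the amine nitrogen. The measured step from compound 1 to compound 2 bears on it only loosely, since it shows that a large exchange at this position left the number unchanged within the scatter. On that basis compound 3 is expected to stay close to compound 2, with a step of a 1.2-fold higher number from compound 2 to compound 3 (0.07 log units; within the scatter) that is not expected to exceed the scatter. Compound 3 is therefore estimated at 6 nM, within a range from 2 nM to 20 nM.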

Compound 3, half-maximal effective concentration: 7.6 nM
For compound 3 the middle estimate is 1.3-fold (0.10 log units) below the measured one, within the range that was stated.
By their numbers in this assay, from the lowest: compounds 2, 1 and 3 (each within the scatter of the next).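

In this assay, the 2-hydroxyethyl on the saturated chain carbon bound to an amine nitrogen and an aromatic carbon can be replaced by hydrogen, with a 1.5-fold higher number from compound 2 to compound 3 (0.17 log units; within the scatter), so compound 2 and compound 3 cannot be told apart and neither the hydroxyl group nor the chain that carries it is shown to matter on this read-out. Phenyl in place of furan-3-yl on a saturated chain carbon bound to an amine nitrogen gives a 1.1-fold higher number from compound 1 to compound 3 (0.03 log units; within the scatter), which isolates the aromatic ring of the group, whereas the earlier step exchanged the whole group at once, and this ring exchange also leaves the two compounds indistinguishable. No independent data bear on why the three compounds read alike.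

Going by these compounds, all three compounds carry an aromatic ring in the group on the amine nitrogen, so it remains open whether the read-out would stay within the scatter with a saturated ring such as cyclohexyl in its place. On these data alone, it is equally open whether an amine, a carboxylic acid or a longer chain in place of the 2-hydroxyethyl would be tolerated as that group was.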